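The compounds below may be only part of what the source reports. "The series", "measured", "known", "first", "only" and "open" are said of these compounds alone.

Compound 1 `Cc1cc(-c2nc3cc(F)ccc3o2)ccc1NC(=O)CCl`: > 100000 nM
Compound 2 `O=C(CCl)Nc1ccc(-c2nc3cc(F)ccc3o2)cc1`: 2990 nM

Both compounds were tested in a functional assay on C6 cells (Rattus norvegicus) for cytotoxicity, read by MTT assay, with a stated time of 24 h; on this read-out higher numbers stand for weaker inhibition and lower numbers for stronger inhibition. For compound 1 the value > 100000 nM is a limit of the assay rather than a measured number (the limit of > 100000 nM in this assay, at which 1 of the 2 values shown sits). Compound 2 gives 2990 nM in this assay. Among the measured compounds shown here, the single measured step between them is an at least 33-fold lower number from compound 1 to compound 2 (1.52 log units; beyond the scatter), a change at the methyl group. Compound 3 `Cc1cc(-c2nc3cc(Cl)ccc3o2)ccc1NC(=O)CCl` keeps the methyl of compound 1 and alters a different site: chloro in place of fluoro on an aromatic carbon. For the measured compounds named here, no measured step covers this exchange, so the step from compound 1 to compound 2 gives no direct guide to its size. What it does show is that compound 1, with the methyl present, reaches only the limit. Because compound 1 stands at > 100000 nM, compound 3 is expected to remain near that limit, with the step of a number no higher from compound 1 to compound 3 (the limit leaves the size open) expected to be small. Compound 3 is therefore estimated at 100000 nM, within 20000 nM to 300000 nM.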

Compound 3, half-maximal inhibitory concentration: > 100000 nM
Compound 3: no number, only a limit; the forecaster's own chance of this, stated with the estimate: 70%; the middle value lies on the limit itself.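

In this assay compound 3 gives > 100000 nM, which is a limit and not a number. Among the compounds shown here, compound 1 and compound 3 both stand at a limit, so no step between them can be read. The compounds shown leave open whether chloro in place of fluoro changes cytotoxicity at all.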